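Aryl Swap on a Triazole Beside the Assay Limit

This account rests on a few compounds, and the source may have more. Where it says the series, first, only, none or still open, it means among the compounds named here.

Compound 1 `N#CC1=C(N)Oc2c(c3nc4ccccc4nc3c3ccccc23)C12C(=O)N(Cc1cnnn1-c1cccc(Br)c1)c1ccccc12`: > 50000 nM
Compound 2 `CC(=O)Nc1ccc(-n2nncc2CN2C(=O)C3(C(C#N)=C(N)Oc4c(N)cc5nc6ccccc6nc5c43)c3ccccc32)cc1`: > 50000 nM

In a functional assay on MCF7 cells (Homo sapiens) for antiproliferative activity, read by MTT assay, with a stated time of 48 h (on this read-out lower numbers stand for stronger inhibition and higher numbers for weaker inhibition), compound 1 reaches only the limit of > 50000 nM. Compound 2 likewise gives only the limit > 50000 nM in this assay, so compound 2 stands at that limit itself, as all values shown do (the limit of > 50000 nM in this assay, at which 2 of the 2 values shown sit). Compound 3 `Cc1ccc(Cl)cc1-n1nncc1CN1C(=O)C2(C(C#N)=C(N)Oc3c(N)cc4nc5ccccc5nc4c32)c2ccccc21` carries 5-chloro-2-methylphenyl in place of 4-acetamidophenyl on an aromatic nitrogen. Within the data shown here, no measured step is at hand, so compound 3 is expected to stay where compound 2 is, with a step that the limit leaves unreadable from compound 2 to compound 3 of no size beyond the scatter. Compound 3 is estimated in this assay at 60000 nM, within 15000 nM to 200000 nM, most likely again reported only as a limit.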

Compound 3, half-maximal inhibitory concentration: 43500 nM
Estimate against measurement, compound 3: 1.4-fold (0.14 log units) above, and the stated range covers the measured number.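

In this assay, among these compounds, compound 3 gives 43500 nM, the only value shown that is not a limit. Putting 5-chloro-2-methylphenyl in place of 4-acetamidophenyl on the aromatic nitrogen gives an at least 1.1-fold lower number from compound 2 to compound 3 (0.06 log units; that floor lies within the scatter), so this change can be read only as a floor and shows no gain beyond the scatter. Most of the values still stand at the limit: the limit of > 50000 nM in this assay, at which 2 of the 3 values shown sit.

From the compounds shown here alone, whether the chlorine or the methyl alone would give the same reading remains open. So does how an amine or a carboxylic acid on this phenyl ring would read.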